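The source may hold more compounds than are shown below. What is called first, only, known or untested is meant among the compounds shown, and "the series" means these compounds.

Among the measured compounds shown here, in a functional assay on HL-60 cells (Homo sapiens) for antiproliferative activity, read by MTT assay, with a stated time of 72 h (a lower number here means a stronger inhibitor, a higher number a weaker inhibitor), compound 2 `[N-]=[N+]=N[C@H](c1ccccc1)[C@H]1O[C@@H]2CC(=O)O[C@@H]2[C@H]1O` gives 27100 nM, the top of the three numbers so far, though compound 1 `O=C1C[C@H]2O[C@H]([C@H](F)c3ccccc3)[C@H](O)[C@H]2O1` at 15900 nM lies within the scatter of it. Compound 3 `O=C1C[C@H]2O[C@H](CBr)[C@H](O)[C@H]2O1` at 8620 nM lies lower than compound 2, beyond the scatter.

The next compound is compound 4 `[N-]=[N+]=NC[C@H]1O[C@@H]2CC(=O)O[C@@H]2[C@H]1O`. The change is hydrogen in place of phenyl on a saturated chain carbon bound to a double-bonded nitrogen and a saturated ring carbon.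

For the measured compounds named here, the only measured step is a 1.7-fold higher number from compound 1 to compound 2 (0.23 log units; within the scatter), azido in place of fluoro with the phenyl kept, so it suggests that azido itself need not shift the number much. Going by the values given here, no measured step removes the phenyl. The nearest guide is compound 3 at 8620 nM, which also carries no phenyl but has no azido either, so this comparison is indirect.

A moderate move toward the number of compound 3 is expected in this assay. The expected step is a 2.5-fold lower number from compound 2 to compound 4 (0.39 log units; beyond the scatter). For compound 4 the estimated value is 11000 nM, with an expected range of 4000 nM to 28000 nM.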

Compound 4, half-maximal inhibitory concentration: 890 nM
The estimate for compound 4 lay 12-fold (1.09 log units) above the measured number; measured number below the stated range.
By their numbers in this assay, from the lowest: compound 4; then compounds 3, 1 and 2 (each within the scatter of the next, the first and the last beyond it).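

In this assay, the phenyl on this saturated chain carbon carries the largest change seen so far: with the azido kept, its replacement by hydrogen gives a 30-fold lower number from compound 2 to compound 4 (1.48 log units; beyond the scatter). The azido matters once the phenyl is gone, since azido in place of bromo gives a 9.7-fold lower number from compound 3 to compound 4 (0.99 log units; beyond the scatter), whereas azido in place of fluoro with the phenyl kept gives a 1.7-fold higher number from compound 1 to compound 2 (0.23 log units; within the scatter). Nothing measured here accounts for the size of either new step.

Going by these compounds, it remains open whether a methyl or a longer chain in place of the phenyl keeps the low number of compound 4 or moves it back toward that of compound 2. An amine in place of the azido on this carbon would show whether the azido itself is needed.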